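The source may report more compounds than this note shows. Statements on the series, on what has been measured and on what is new or still open speak of the compounds shown alone.

Compound 1 `CCN(Cc1c[nH]nn1)C(=O)COc1ccc(C)cc1` and compound 2 `Cc1ccc(OCC(=O)N(Cc2cccs2)c2ccnn2C)cc1` share a core and were tested in an assay on HEK293 cells for agonist activity at transient receptor potential cation channel subfamily M member 8 (Homo sapiens), read by fluorescence and calcium flux, with a stated time of 15 min; a higher number here means that more compound is needed for the effect, a lower number that less compound is needed. In this assay compound 1 gives 31100 nM, whereas compound 2 gives 422 nM, the lowest number of the two and well beyond the scatter from compound 1. Compound 3 `C=CCN(Cc1cccs1)C(=O)COc1ccc(C)cc1` differs from compound 2 in one place: allyl in place of 1-methyl-1H-pyrazol-5-yl on an amide-type nitrogen. Within the data shown here, no measured pair shows this change alone, so its size can only be estimated; a moderate rise in the number is expected, as a 2.8-fold higher number from compound 2 to compound 3 (0.45 log units; beyond the scatter). Compound 3 is therefore expected to give about 1200 nM, within 400 nM to 4000 nM.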

Compound 3, half-maximal effective concentration: 20 nM
Compound 3: middle estimate off by 60-fold (1.78 log units), on the high side; the whole stated range lies above it.
By their numbers in this assay, from the lowest: compound 3; then compound 2; then compound 1.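

On the amide-type nitrogen, allyl in place of 1-methyl-1H-pyrazol-5-yl gives a 21-fold lower number from compound 2 to compound 3 (1.32 log units; beyond the scatter) in this assay. This position therefore does not need a five-membered aromatic ring for a low number, and an open chain with one double bond does far better here. No measurement on hand explains why this step is so large.

The compounds shown leave open whether the double bond of allyl matters, since a saturated propyl chain would be needed to test that. From the compounds shown here alone, how a longer chain, such as butyl, or a chain carrying an amine would fare at this nitrogen also remains unknown.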